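Aryl swap on the saturated ring carbon

The compounds below may be only part of what the source reports. "The series", "measured", "known", "first", "only" and "open" are said of these compounds alone.

Compound 1 `COc1ccc(-n2nc(Sc3ccc(Cl)cc3)cc(CC[C@@H](C)NC(=O)[C@H]3CNCC[C@@H]3c3cccc(Cl)c3)c2=O)cc1` gives 680 nM in a functional assay with Melanocortin receptor 4 (Homo sapiens) as the target, read by cAMP accumulation; a lower number here means that less compound is needed, a higher number that more compound is needed for the effect. Compound 2 `COc1ccc(-n2nc(Sc3ccc(Cl)cc3)cc(CC[C@@H](C)NC(=O)[C@H]3CNCC[C@@H]3c3ccccc3F)c2=O)cc1` gives 550 nM, the lowest of the two numbers, but the step of a 1.2-fold lower number from compound 1 to compound 2 (0.09 log units; within the scatter) stays within the scatter. Compound 3 `COc1ccc(-n2nc(Sc3ccc(Cl)cc3)cc(CC[C@@H](C)NC(=O)[C@H]3CNCC[C@@H]3c3ccc(C(F)(F)F)cc3)c2=O)cc1` carries 4-(trifluoromethyl)phenyl in place of 2-fluorophenyl on a saturated ring carbon. Among the compounds with values here, the only measured step bearing on this change is the earlier aryl exchange on the same saturated ring carbon, a 1.2-fold lower number from compound 1 to compound 2 (0.09 log units; within the scatter), which did not move beyond the scatter; a shift beyond the scatter in this assay is therefore not expected. Compound 3 is expected at 600 nM, with a range of 250 nM to 1500 nM. The estimated step of a 1.1-fold higher number from compound 2 to compound 3 (0.04 log units; within the scatter) is expected to stay within the scatter.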

Compound 3, half-maximal effective concentration: > 5000 nM
Compound 3 was reported as a limit; the forecaster's own chance of this, stated with the estimate: 3%; middle value at least 8.3-fold (0.92 log units) away from the limit.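

The saturated ring carbon is not indifferent to its aryl group: the change to 4-(trifluoromethyl)phenyl gives an at least 9.0-fold higher number from compound 2 to compound 3 (0.95 log units; beyond the scatter) and an at least 7.3-fold higher number from compound 1 to compound 3 (0.86 log units; beyond the scatter), although the earlier exchange between 3-chlorophenyl and 2-fluorophenyl stayed within the scatter. Compound 3 is reported only as a limit, not a number: the limit of > 5000 nM in this assay, at which 1 of the 3 values shown sits.

Both steps alter the substituent and its place on the phenyl ring together, so the rise cannot be assigned to either alone. Open, from the compounds shown here alone, is whether 3-(trifluoromethyl)phenyl, 4-fluorophenyl or unsubstituted phenyl would stay near compound 2 or follow compound 3.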